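The source may report more compounds than this note shows. Statements on the series, on what has been measured and on what is new or still open speak of the compounds shown alone.

Working notes on the series. Compound 1 `COc1ccc(/C=C/C(=O)c2ccccc2-c2ccc(F)cc2)cc1OC` is the reference. In a functional assay on CNE-2 cells (Homo sapiens) for antiproliferative activity, read by sulforhodamine B assay, with a stated time of 48 h (on this read-out lower numbers stand for stronger inhibition and higher numbers for weaker inhibition), compound 1 gives 81 nM. Compound 2 `COc1ccc(/C=C/C(=O)c2ccccc2-c2ccc(F)nc2)cc1OC` carries 6-fluoropyridin-3-yl in place of 4-fluorophenyl on an aromatic carbon; in this assay compound 2 gives 1600 nM, so the change produced a 20-fold higher number from compound 1 to compound 2 (1.30 log units; beyond the scatter). Compound 3 `COc1ccc(C(=O)/C=C/c2ccccc2-c2ccc(F)cc2)cc1OC` has the same atoms as compound 1 joined differently; the difference between the two cores is not broken down here. In this assay compound 3 gives 7600 nM, the highest number of the three. Compound 4 `COc1ccc(C(=O)/C=C/c2ccccc2-c2ccc(F)nc2)cc1OC` carries, on the core of compound 3, the same change, (6-fluoropyridin-3-yl in place of 4-fluorophenyl on an aromatic carbon). A step of a 7.9-fold higher number from compound 3 to compound 4 (0.90 log units; beyond the scatter) is expected, resting on the earlier step because a 20-fold higher number from compound 1 to compound 2 (1.30 log units; beyond the scatter) was seen on the core of compound 1. In this assay compound 4 is therefore expected near 60000 nM, estimated between 12000 nM and 250000 nM.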

Compound 4, half-maximal inhibitory concentration: 17000 nM
Compound 4: the middle estimate sits 3.5-fold (0.55 log units) above what was measured; the range from low to high includes it.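

In this assay the change again moves the number the same way, with a 2.2-fold higher number from compound 3 to compound 4 (0.35 log units; beyond the scatter). The direction therefore carries over between these two cores, but the size of the step does not: the same change on two cores in this assay, a 20-fold higher number (1.30 log units; beyond the scatter) from compound 1 to compound 2 and a 2.2-fold higher number (0.35 log units; beyond the scatter) from compound 3 to compound 4, 8.8-fold (0.95 log units) apart, beyond the scatter of two such steps. Two cores give no rule for any further core, and these data do not show what sets the size of the step on either one.

As far as these compounds go, whether an amine or a carboxylic acid in place of the fluorine on the 6-fluoropyridin-3-yl ring would follow the same direction on both cores stays open. Also open, from the compounds shown here alone, is whether the gap between the two steps would persist with a different aromatic ring in this position.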